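The source may hold more compounds than are shown below. What is called first, only, known or untested is meant among the compounds shown, and "the series" means these compounds.

Measured values in an ADME assay on MT4 cells (Homo sapiens) for cytotoxicity, read by MTT assay; on this read-out higher numbers stand for lower toxicity in this test and lower numbers for higher toxicity in this test:

compound 1 `Cc1cc(C)cc(S(=O)(=O)c2c(C(=O)NC(C)C(=O)NCCn3c(C)cnc3[N+](=O)[O-])[nH]c3ccc(Cl)cc23)c1`: 16000 nM
compound 2 `Cc1cc(C)cc(S(=O)(=O)c2c(C(=O)NC(C)C(=O)NC(C)c3ccccc3)[nH]c3ccc(Cl)cc23)c1`: 21700 nM
compound 3 `Cc1cc(C)cc(S(=O)(=O)c2c(C(=O)NC(C)C(=O)NCc3ccncc3)[nH]c3ccc(Cl)cc23)c1`: 19500 nM

The three numbers sit close together. Compound 3 differs from compound 1 by a 1.2-fold higher number from compound 1 to compound 3 (0.09 log units; within the scatter) and from compound 2 by a 1.1-fold lower number from compound 2 to compound 3 (0.05 log units; within the scatter), so nothing separates it from either beyond the scatter; likewise a 1.4-fold higher number from compound 1 to compound 2 (0.13 log units; within the scatter) is within the scatter. Exchanging the terminal group carried on the amide-type nitrogen, or on the saturated chain carbon bound to it, has so far left the cytotoxicity read-out unchanged within its scatter.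

Compound 4 `Cc1cc(C)cc(S(=O)(=O)c2c(C(=O)NCc3ccc4nc(N)[nH]c4c3)[nH]c3ccc(Cl)cc23)c1` continues this pattern of replacing the terminal amide substituent: a group of 11 heavy atoms (8 carbon, 3 nitrogen; one five-membered aromatic ring with 2 hetero atoms, one six-membered aromatic ring of carbon only) in place of a group of 12 heavy atoms (9 carbon, 2 nitrogen, 1 oxygen; one six-membered aromatic ring with 1 hetero atom), on an amide-type nitrogen. The steps from compound 1 to compound 2 and from compound 2 to compound 3 are the ones that bear on this change, and both were within the scatter. The step of a 1.0-fold lower number from compound 3 to compound 4 (0.01 log units; within the scatter) is therefore expected to be of no consequence beyond the scatter, in either direction. Compound 4 is estimated at 19000 nM, with a range from 9500 nM to 40000 nM.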

Compound 4, half-maximal cytotoxic concentration: 5890 nM
For compound 4 the middle estimate is 3.2-fold (0.51 log units) above the measured one; the whole stated range lies above it.
By their numbers in this assay, from the lowest: compound 4; then compounds 1, 3 and 2 (each within the scatter of the next).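

In this assay, within the data shown here, the change on the amide-type nitrogen gives a 3.3-fold lower number from compound 3 to compound 4 (0.52 log units; beyond the scatter) and thus a modest shift toward higher toxicity in this test, so this place can move the read-out, which no step among compound 1, compound 2 and compound 3 showed. Among these compounds, the change is more than an exchange of rings: the group that leaves holds a double bond outside aromatic rings, the group that enters holds none, and the single step does not separate these differences. No measurement shown accounts for the step.

Only compound 4 carries the entering group, so one step stands for this change and it cannot yet be called a trend. Open, on these data alone, is whether a benzyl group, or a longer chain ending in a carboxylic acid, on the same amide-type nitrogen would keep the read-out with compound 3 or with compound 4.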